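The source may report more compounds than this note shows. Statements on the series, on what has been measured and on what is new or still open speak of the compounds shown alone.

In an ADME assay on the whole organism for inhibition, with Echinochloa crus-galli var. formosensis as the target, with a stated time of 4 days (on this read-out higher numbers stand for weaker inhibition and lower numbers for stronger inhibition), compound 1 `CCNc1nc(Cl)nc(N[C@H](C)c2ccccc2)n1` gives 2690 nM, compound 2 `CCCNc1nc(Cl)nc(N[C@H](C)c2ccccc2)n1` gives 33100 nM, and compound 3 `CNc1nc(Cl)nc(N[C@H](C)c2ccccc2)n1` gives 562 nM, the lowest number of the three. Compound 4 `CC(C)Nc1nc(Cl)nc(N[C@H](C)c2ccccc2)n1`, not yet measured, has isopropyl in place of methyl on a nitrogen on an aromatic ring. Within the data shown here, three measured steps bear on this change. Lengthening the chain gave a 12-fold higher number from compound 1 to compound 2 (1.09 log units; beyond the scatter), while shortening it gave a 4.8-fold lower number from compound 1 to compound 3 (0.68 log units; beyond the scatter) and a 59-fold lower number from compound 2 to compound 3 (1.77 log units; beyond the scatter). None of these three compounds goes against this trend, but none carries a branched chain, so the size remains uncertain. A large step to a higher number is expected, and the estimated step is a 14-fold higher number from compound 3 to compound 4 (1.15 log units; beyond the scatter). For compound 4 the expected value is 8000 nM, with an estimated range from 1500 nM to 40000 nM.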

Compound 4, half-maximal inhibitory concentration: 2000 nM
Compound 4: middle estimate off by 4.0-fold (0.60 log units), on the high side; the measured number falls inside the stated range.
By their numbers in this assay, from the lowest: compound 3; then compounds 4 and 1 (each within the scatter of the next); then compound 2.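

In this assay, the branched isopropyl on this nitrogen gives a 3.6-fold higher number from compound 3 to compound 4 (0.55 log units; beyond the scatter) and so still reads higher than methyl, but the change from straight propyl gives a 17-fold lower number from compound 2 to compound 4 (1.22 log units; beyond the scatter). Thus, the large rise seen with propyl does not follow from chain size alone. Adding the branching methyl to the ethyl chain gives a 1.3-fold lower number from compound 1 to compound 4 (0.13 log units; within the scatter) and leaves the two compounds within the scatter of each other. Nothing available here accounts for the gap between the branched and straight chains. The compounds shown leave open how a cyclopropyl or tert-butyl group on this nitrogen would read.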